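Methylsulfonyl in place of the earlier group at compound 3

The source may hold more compounds than are shown below. What is called first, only, known or untested is meant among the compounds shown, and "the series" means these compounds.

Measured in a functional assay on the whole organism for antagonist activity, with Mus musculus as the target; a lower number here means that less compound is needed, a higher number that more compound is needed for the effect:
compound 1 `CSc1nnc(-c2cccc3ccccc23)n1C`: > 200 mg/kg
compound 2 `Cn1c(-c2cccc3ccccc23)nnc1[S+](C)[O-]`: > 200 mg/kg

Compound 1 stands at > 200 mg/kg, which is a limit and not a number. Compound 2 likewise stands at > 200 mg/kg, also a limit. The whole record so far is the limit of > 200 mg/kg in this assay, at which 2 of the 2 values shown sit.

Compound 3 `Cn1c(-c2cccc3ccccc23)nnc1S(C)(=O)=O` differs from compound 2 by one change: a group of 4 heavy atoms (1 carbon, 2 oxygen, 1 sulfur; no ring) in place of a group of 3 heavy atoms (1 carbon, 1 oxygen, 1 sulfur; no ring), on an aromatic carbon. Among the measured compounds shown here, the only measured step at this place is a step that the two limits leave unreadable from compound 1 to compound 2. It offers no size to carry forward, so no direction can be expected in this assay on these data. The expected step is a number no higher from compound 2 to compound 3 (the limit leaves the size open). For compound 3 the estimated value is 200 mg/kg. The expected range for compound 3 runs from 60 mg/kg to 400 mg/kg. Another limit is the likeliest report.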

Compound 3, dose for half-maximal effect: > 200 mg/kg
Compound 3 ended at the assay's limit (the forecaster's own chance of this, stated with the estimate: 65%); the middle value sits exactly at the limit.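

No new step can be read among compound 1, compound 2 and compound 3 in this assay, as each result is a limit and not a number: the limit of > 200 mg/kg in this assay, at which 3 of the 3 values shown sit.

The compounds shown leave open whether the group on this aromatic carbon affects the dose needed, and by how much.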